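The compounds below may be only part of what the source reports. "The series", "measured", "known", "first", "only" and "open" are said of these compounds alone.

For the measured compounds named here, compound 2, with the structure `c1cnc(-c2ccccc2NCC2=NCCN2)nc1`, gives 81.3 nM in a functional assay for activation of Alpha-1D adrenergic receptor (Homo sapiens) (a lower number here means that less compound is needed, a higher number that more compound is needed for the effect), and this is the only plain number in the set. Compound 1, with the structure `Cc1noc(-c2ccccc2NCC2=NCCN2)n1`, reaches only a limit of < 5020 nM in this assay. The change a step that the limit leaves unreadable from compound 1 to compound 2 therefore cannot be sized because the limit of < 5020 nM in this assay, at which 1 of the 2 values shown sits, leaves the starting point open. Compound 3, with the structure `CC/C(=N\OC)c1ccccc1NCC1=NCCN1`, carries a group of 6 heavy atoms (4 carbon, 1 nitrogen, 1 oxygen; no ring) in place of a group of 6 heavy atoms (4 carbon, 2 nitrogen; one six-membered aromatic ring with 2 hetero atoms), on an aromatic carbon. Going by the values given here, no measured step speaks directly to this exchange of an aromatic ring for an open chain, and the one step recorded is unreadable, so the expectation rests on compound 2 alone. The author expects a loss in potency of about a 3.7-fold higher number from compound 2 to compound 3 (0.57 log units; beyond the scatter) for compound 3, with wide uncertainty. Compound 3 is thus estimated at 300 nM, between 60 nM and 2000 nM.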

Compound 3, half-maximal effective concentration: < 100000 nM
Compound 3 was reported as a limit (the forecaster's own chance of this, stated with the estimate: 15%); the middle value lies beyond the limit too.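

In this assay compound 3 is reported only as a limit, < 100000 nM. The steps to compound 3 from compound 1 and from compound 2 cannot be read. The compounds shown leave open how far replacing pyrimidin-2-yl with the open chain of compound 3 changes potency.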